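The source may hold more compounds than are shown below. What is called first, only, known or untested is meant among the compounds shown, and "the series" means these compounds.

Working notes on the series. Compound 1 `C[C@H]1[C@H](NCc2cc(Br)cs2)C[C@H]2C[C@@H]1C2(C)C` and compound 2 `C[C@H]1[C@H](NCc2sccc2-c2ccccc2)C[C@H]2C[C@@H]1C2(C)C` share one core and differ only in the substituent on the five-membered aromatic ring carrying the amine linker. In an ADME assay on MDCK cells (Canis lupus familiaris) for cytotoxicity, read by microscopy, with a stated time of 48 h (on this read-out lower numbers stand for higher toxicity in this test and higher numbers for lower toxicity in this test), compound 1 gives 6250 nM. In this assay, going by the values given here, compound 2 gives 12500 nM, the higher of the two numbers recorded so far; compound 1 is its only neighbour, and the two values lie within the usual scatter of repeated measurements, so no order between them can be read from these data.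

The step under consideration leads from compound 2 to compound 3 `C[C@H]1[C@H](NCc2cccs2)C[C@H]2C[C@@H]1C2(C)C`. The change is hydrogen in place of phenyl on an aromatic carbon. Among the compounds with values here, no measured pair in the set shares this change, so there is nothing to copy a step from; what can be said is that the one substituent swap already measured, from bromine to phenyl at the same ring position, did not move the read-out beyond the scatter.

On this basis the step expected in this assay from compound 2 to compound 3 is a 1.2-fold higher number from compound 2 to compound 3 (0.08 log units; within the scatter), that is, none beyond the scatter, if anything a slightly higher number. For compound 3 in this assay the expected value is 15000 nM, with a range from 4000 nM to 50000 nM.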

Compound 3, minimum cytotoxic concentration: 25000 nM
Estimate against measurement, compound 3: 1.7-fold (0.22 log units) below; the range from low to high includes it.
By their numbers in this assay, from the lowest: compounds 1, 2 and 3 (each within the scatter of the next, the first and the last beyond it).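

In this assay, taking phenyl off the aromatic carbon next to the ring atom that bears a large group, two ring bonds from the ring sulfur, gives a 2.0-fold higher number from compound 2 to compound 3 (0.30 log units; within the scatter), so this carbon shows no effect of phenyl that can be told from the scatter. Going by these compounds alone, the step with bromo gives a 4.0-fold higher number from compound 1 to compound 3 (0.60 log units; beyond the scatter), the first step beyond the scatter, though only a modest one, and it shows that hydrogen in place of a single substituent on this ring can register in the read-out. No supporting data bear on why bromo and phenyl give steps of different size, and these two steps differ in the group that leaves, so neither can be carried over to the other.

The compounds shown leave open whether a methyl, an amine or a carboxylic acid on the same aromatic carbon would give a step beyond the scatter from compound 3. They also leave open how bromo would read at the carbon that carries phenyl in compound 2, and whether any change to the amine linker or the shared core would move this read-out.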